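Adding a carbon at the saturated chain of compound 2

The source may report more compounds than this note shows. Statements on the series, on what has been measured and on what is new or still open speak of the compounds shown alone.

Of the compounds shown here, two have been measured in an ADME assay on cells for inhibition of cytochrome P450 11B1, mitochondrial (Homo sapiens), read by HTRF; on this read-out lower numbers stand for stronger inhibition and higher numbers for weaker inhibition. Compound 1, with the structure `CC[C@H]1c2cc(Cl)ccc2C(=O)N1c1cncc2c1CCC[C@H]2NC(C)=O`, gives 3630 nM in this assay. Compound 2, with the structure `CCC(=O)N[C@@H]1CCCc2c1cncc2N1C(=O)c2ccc(Cl)cc2[C@@H]1C`, gives 414 nM in this assay, the lower of the two numbers and therefore the stronger inhibitor of the pair; the number for compound 1 is higher by a step that lies beyond the usual scatter of this kind of measurement.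

Compound 3, with the structure `CCC(=O)N[C@@H]1CCCc2c1cncc2N1C(=O)c2ccc(Cl)cc2[C@@H]1CC`, has not yet been measured in this assay. It differs from compound 2 in a single place: methyl in place of hydrogen on a saturated chain carbon bound to a saturated ring carbon. Put another way, the group at that place grows from methyl to ethyl.

Going by the values given here, no measured pair shows what such a change does here, so the direction of the step is open. A change this small is expected to move the number only modestly, and the estimate keeps compound 3 close to compound 2, with the step of a 1.9-fold higher number from compound 2 to compound 3 (0.29 log units; within the scatter) allowing either a small loss or a small gain. On this basis compound 3 is expected to give about 800 nM in this assay, within a range from 250 nM to 2500 nM.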

Compound 3, half-maximal inhibitory concentration: 345 nM
The estimate for compound 3 lay 2.3-fold (0.37 log units) above the measured number; the measured number falls inside the stated range.
By their numbers in this assay, from the lowest: compounds 3 and 2 (each within the scatter of the next); then compound 1.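

In this assay the growth from methyl to ethyl, on a saturated chain carbon bound to a saturated ring carbon, gives a 1.2-fold lower number from compound 2 to compound 3 (0.08 log units; within the scatter) and so leaves the two compounds indistinguishable: this place accepts the ethyl group as readily as the methyl group. The same kind of change, methyl in place of hydrogen, behaves very differently on a saturated chain carbon bound to a carbonyl carbon, where an 11-fold lower number from compound 1 to compound 3 (1.02 log units; beyond the scatter) is a large step. Among these steps, then, the added carbon matters on the chain attached to the carbonyl and not on the chain attached to the ring, and nothing available here gives a reason for that contrast.

Only methyl and ethyl are shown at the ring-bound place, so it remains open whether a longer chain such as propyl, or a small ring such as cyclopropyl, would also leave the number unchanged. From the compounds shown here alone, on the carbonyl side, it also remains open whether a further carbon, as in a butanoyl group, would extend the large step or reverse it.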